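The source may report more compounds than this note shows. Statements on the series, on what has been measured and on what is new or still open speak of the compounds shown alone.

Of the compounds shown here, three sharing one core have been tested in an ADME assay on HEK293 cells (Homo sapiens) for cytotoxicity, read by luminescence, with a stated time of 72 h; a higher number here means that more compound is needed for the effect, a lower number that less compound is needed: compound 1 (`CCOC(=O)c1c(-c2cccc(OC)c2)[nH]c2cc(OC)ccc2c1=O`), compound 2 (`CCOC(=O)c1c(-c2cccc(OC)c2)[nH]c2cc(OC)c(OC)cc2c1=O`) and compound 3 (`CCOC(=O)c1c(-c2cccc(OC)c2)[nH]c2cc(OC)c(F)cc2c1=O`). Compound 1 gives > 22000 nM, which is a limit and not a number. Compound 2 gives > 22000 nM, which is also a limit. Compound 3 gives > 22000 nM, again a limit, so it has no exact position on the scale. All the measurements so far rest on (the limit of > 22000 nM in this assay, at which 3 of the 3 values shown sit).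

The next compound is compound 4 (`CCOC(=O)c1c(-c2cccc(Br)c2)[nH]c2cc(OC)c(F)cc2c1=O`), which carries 3-bromophenyl where compound 3 carries 3-methoxyphenyl: bromo in place of methoxy on an aromatic carbon. In words, this is bromo in place of methoxy on an aromatic carbon.

Three measured steps are available: a step that the two limits leave unreadable from compound 1 to compound 2, a step that the two limits leave unreadable from compound 1 to compound 3 and a step that the two limits leave unreadable from compound 2 to compound 3. All three compounds keep the 3-methoxyphenyl group, so none of these steps tests the change at hand, and none has a readable size. They offer only indirect guidance: three changes of substituent, and every result stayed at the limit. No clear step in either direction is therefore expected in this assay, and a further limit is the likeliest report. The expected change is a step that the limit leaves unreadable from compound 3 to compound 4. For compound 4 the estimated value is 25000 nM, with an expected range from 9000 nM to 60000 nM.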

Compound 4, half-maximal effective concentration: > 22000 nM
Compound 4: no number, only a limit; the forecaster's own chance of this, stated with the estimate: 75%; the middle value is on the limit's open side.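

No new step can be read: compound 3 and compound 4 each give only a limit and not a number in this assay, so the size of the change between them stays hidden: the limit of > 22000 nM in this assay, at which 4 of the 4 values shown sit. The compounds shown leave open whether bromo in place of methoxy makes any difference to the concentration needed for the effect.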